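The source may hold more compounds than are shown below. What is called first, only, known or untested is meant among the compounds shown, and "the series" means these compounds.

Measured compounds in a functional assay on HeLa cells (Homo sapiens) for cytotoxicity, read by MTT assay, with a stated time of 72 h; on this read-out lower numbers stand for stronger inhibition and higher numbers for weaker inhibition: compound 1 `COc1cccc(/C=C/C(=O)Nc2cc(OC)c(OC)c(OC)c2)c1` gives 12300 nM; compound 2 `COc1ccc(C(=O)c2cc(OC)c(OC)c(OC)c2)cc1NC(=O)/C=C/c1ccc(OC)c(OC)c1` gives 7800 nM; compound 3 `COc1ccc(/C=C/C(=O)Nc2cc(C(=O)c3cc(OC)c(OC)c(OC)c3)ccc2OC)cc1` gives 10700 nM.

Compound 2 has the lowest number of the three, but its gaps to compound 3 and to compound 1 both lie within the scatter, so none of the three can be called stronger than another. Compound 4 `COc1cc(/C=C/C(=O)Nc2cc(C(=O)c3cc(OC)c(OC)c(OC)c3)ccc2OC)ccc1F` is compound 2 with one change: fluoro in place of methoxy on an aromatic carbon. Among the measured compounds shown here, only one measured step bears on this: a 1.4-fold higher number from compound 2 to compound 3 (0.14 log units; within the scatter), which also exchanged a methoxy group and left the number essentially unchanged. For the measured compounds named here, no measured compound carries a fluoro, so the expectation rests on that step alone, and a step of a 1.0-fold higher number from compound 2 to compound 4 (0.01 log units; within the scatter) is expected, nothing beyond the scatter. Compound 4 is therefore estimated at 8000 nM, between 3000 nM and 20000 nM.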

Compound 4, half-maximal inhibitory concentration: 13600 nM
For compound 4 the middle estimate is 1.7-fold (0.23 log units) below the measured one; the measured number falls inside the stated range.
By their numbers in this assay, from the lowest: compounds 2, 3, 1 and 4 (each within the scatter of the next).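

In this assay, fluoro in place of methoxy at this position gives a 1.7-fold higher number from compound 2 to compound 4 (0.24 log units; within the scatter) and so stays within the scatter: the two groups cannot be told apart here. Hydrogen at the same position, with the 4-methoxyphenyl of compound 3, gives a 1.3-fold higher number from compound 3 to compound 4 (0.10 log units; within the scatter) against the 4-fluoro-3-methoxyphenyl, so all three groups now tried here read alike. No measured evidence explains these numbers.

Only methoxy, hydrogen and fluoro appear at this position. As far as these compounds go, whether an amine or a carboxylic acid there would move the number beyond the scatter remains open.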